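This account rests on a few compounds, and the source may have more. Where it says the series, first, only, none or still open, it means among the compounds named here.

Working notes on the series, read in a functional assay (QGY7701 cells, Homo sapiens) for inhibition, read by MTT assay, with a stated time of 48 h; on this read-out lower numbers stand for stronger inhibition and higher numbers for weaker inhibition. Within the data shown here, compound 1 `O=C(/C=C/c1coc2cc(O)ccc2c1=O)NCc1ccccc1` gives 63000 nM, the higher of the two numbers measured so far and therefore the weaker inhibition. Compound 2 `Cc1ccccc1NC(=O)/C=C/c1coc2cc(O)ccc2c1=O` gives 9320 nM. Compound 3 `O=C(/C=C/c1coc2cc(O)ccc2c1=O)NCc1ccc(F)cc1F` has not yet been measured. It keeps the core of compound 1 and differs only in the aromatic group: 2,4-difluorophenyl in place of phenyl on a saturated chain carbon bound to an amide-type nitrogen. In words, this places 2,4-difluorophenyl in place of phenyl on a saturated chain carbon bound to an amide-type nitrogen.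

Among the measured compounds shown here, one measured step bears on this change: a 6.8-fold lower number from compound 1 to compound 2 (0.83 log units; beyond the scatter), with 2-methylphenyl in place of benzyl on an amide-type nitrogen. That step alters the same substituent but leaves no saturated chain carbon, so it is only a loose guide. For the measured compounds named here, no measured compound carries fluorine. A shift toward a lower number is expected in this assay, smaller than the step to compound 2, and a result within the scatter of compound 1 remains possible. The estimated step is a 2.1-fold lower number from compound 1 to compound 3 (0.32 log units; beyond the scatter). For compound 3 the estimated value is 30000 nM, with an expected range from 10000 nM to 80000 nM.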

Compound 3, half-maximal inhibitory concentration: > 100000 nM
Compound 3: no number, only a limit; the forecaster's own chance of this, stated with the estimate: 15%; middle value at least 3.3-fold (0.52 log units) from the limit.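

Compound 3 gives no number in this assay, only a limit of the assay: the limit of > 100000 nM in this assay, at which 1 of the 3 values shown sits. The step is an at least 1.5-fold higher number from compound 1 to compound 3 (0.20 log units; that floor lies within the scatter), so 2,4-difluorophenyl in place of phenyl on a saturated chain carbon bound to an amide-type nitrogen brings no measurable gain in inhibition, although the floor of that step alone does not separate compound 3 from compound 1. Among these compounds, this is the first fluorine-bearing compound, and its result shows that a substituted phenyl on this chain carbon does not by itself give a lower number, so the drop in a 6.8-fold lower number from compound 1 to compound 2 (0.83 log units; beyond the scatter) finds no parallel here and remains a single observation tied to 2-methylphenyl on the amide-type nitrogen.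

As far as these compounds go, how far the true value of compound 3 lies past its limit stays open, and with it the size of the step from compound 1. The compounds shown also leave open whether 2-fluorophenyl, 4-fluorophenyl, a methoxy-bearing phenyl or a longer chain between the amide-type nitrogen and the ring would read differently in this assay.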